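A few compounds are considered here, and "the series" means these few. Any claim that something is new, unique, unknown or untested is made for them only; others in the source may bear on it.

Compound 1, `COc1cc2c(Nc3ccc(C#N)cc3)ncnc2cc1OCCCN1CCN(C)CC1`, is the starting point of this small set. In a functional assay on MCF7 cells (Homo sapiens) for antiproliferative activity, read by MTT assay, with a stated time of 72 h (a lower number here means a stronger inhibitor, a higher number a weaker inhibitor), compound 1 gives 71100 nM. Compound 2, `CCN1CCN(CCCOc2cc3ncnc(Nc4ccc(C#N)cc4)c3cc2OC)CC1`, differs from compound 1 only by methyl in place of hydrogen on a saturated chain carbon bound to an amine nitrogen in a ring, and in this assay compound 2 gives 29900 nM; that change produced a 2.4-fold lower number from compound 1 to compound 2 (0.38 log units; beyond the scatter). Compound 3, `COc1cc2c(Nc3ccccc3C#N)ncnc2cc1OCCCN1CCN(C)CC1`, keeps the chain and ring of compound 1 but carries 2-cyanophenyl in place of 4-cyanophenyl on a nitrogen on an aromatic ring; in this assay compound 3 gives 17800 nM, which is a 4.0-fold lower number from compound 1 to compound 3 (0.60 log units; beyond the scatter). Compound 3 has the lowest number of the three, but its gap to compound 2 lies within the scatter, so no order between compound 2 and compound 3 can be read.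

Compound 4, `CCN1CCN(CCCOc2cc3ncnc(Nc4ccccc4C#N)c3cc2OC)CC1`, has not yet been measured. It differs from compound 3 by methyl in place of hydrogen on a saturated chain carbon bound to an amine nitrogen in a ring, the same change already seen from compound 1 to compound 2, at the same place. The cores of the two pairs differ by 2-cyanophenyl in place of 4-cyanophenyl on a nitrogen on an aromatic ring. Among the measured compounds shown here, whether this change carries over to the other core is known from only one measured pair, so any expectation rests on a single precedent. The estimate for compound 4 takes compound 3 at 17800 nM and applies the step of a 2.4-fold lower number from compound 1 to compound 2 (0.38 log units; beyond the scatter). The step from compound 3 to compound 4 in this assay is expected to be about a 2.4-fold lower number from compound 3 to compound 4 (0.38 log units; beyond the scatter). Compound 4 is estimated to give around 7500 nM in this assay. The expected range for compound 4 runs from 3000 nM to 18000 nM.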

Compound 4, half-maximal inhibitory concentration: 9070 nM
For compound 4 the middle estimate is 1.2-fold (0.08 log units) below the measured one, within the range that was stated.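

In this assay, methyl in place of hydrogen on the saturated chain carbon bound to the ring amine nitrogen gives a 2.0-fold lower number from compound 3 to compound 4 (0.29 log units; within the scatter) on the core bearing 2-cyanophenyl, and this step agrees with the earlier one on the core bearing 4-cyanophenyl: the same change on two cores in this assay, a 2.4-fold lower number (0.38 log units; beyond the scatter) from compound 1 to compound 2 and a 2.0-fold lower number (0.29 log units; within the scatter) from compound 3 to compound 4, 1.2-fold (0.08 log units) apart, within the scatter of two such steps. The change of 4-cyanophenyl to 2-cyanophenyl, read with 4-ethylpiperazin-1-yl in place, gives a 3.3-fold lower number from compound 2 to compound 4 (0.52 log units; beyond the scatter) and also agrees with its earlier counterpart: the same change on two cores in this assay, a 4.0-fold lower number (0.60 log units; beyond the scatter) from compound 1 to compound 3 and a 3.3-fold lower number (0.52 log units; beyond the scatter) from compound 2 to compound 4, 1.2-fold (0.08 log units) apart, within the scatter of two such steps. Across these four compounds, each change therefore carried over from one core to the other with no difference that can be read, but this rests on a single pair of steps for each change, and it does not show that either change would carry over to any other core, while the step to compound 4 from compound 3 taken alone does not set those two compounds apart.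

The compounds shown leave open whether propyl or benzyl in place of the ethyl of 4-ethylpiperazin-1-yl would extend the same step. They also leave open whether a chlorine or an amide in place of the nitrile would behave as the cyanophenyl groups do.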